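Expected cytotoxicity of compound 4 after the amide swap

The source may report more compounds than this note shows. Statements on the series, on what has been measured and on what is new or still open speak of the compounds shown alone.

Compound 1, `CC(C)n1ncc2c(C(=O)N3CCc4cccnc43)cc(-c3cccs3)nc21`: 50000 nM
Compound 2, `CC(C)n1ncc2c(C(=O)Nc3ccc(F)cc3)cc(-c3cccs3)nc21`: > 200000 nM
Compound 3, `CC(C)n1ncc2c(C(=O)Nc3cncnc3)cc(-c3cccs3)nc21`: 20000 nM

All three share one core and differ only in the group on the amide-type nitrogen. In an ADME assay on LLC-MK2 cells (Macaca mulatta) for cytotoxicity, read by spectrophotometry and crystal violet staining, with a stated time of 4 days (on this read-out lower numbers stand for higher toxicity in this test and higher numbers for lower toxicity in this test), compound 1 gives 50000 nM and compound 3 gives 20000 nM. Compound 2 sits at the limit of > 200000 nM in this assay, at which 1 of the 3 values shown sits, which is a limit of the test and not a number. Of the two numbers, compound 3 holds the lowest, and the nearest is compound 1: a 2.5-fold lower number from compound 1 to compound 3 (0.40 log units; beyond the scatter).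

Compound 4, `CC(C)n1ncc2c(C(=O)Nc3ccccc3S(N)(=O)=O)cc(-c3cccs3)nc21`, carries 2-sulfamoylphenyl in place of pyrimidin-5-yl on an amide-type nitrogen. Within the data shown here, two measured steps bear on this change. an at least 10-fold lower number from compound 2 to compound 3 (1.00 log units; beyond the scatter) shows that replacing a six-membered aromatic ring of carbon only by pyrimidin-5-yl brought the number down; compound 4 runs the other way, bringing back a six-membered aromatic ring of carbon only. a 2.5-fold lower number from compound 1 to compound 3 (0.40 log units; beyond the scatter) also moved the number down toward compound 3. A step upward from compound 3 is therefore expected, though 2-sulfamoylphenyl is not 4-fluorophenyl, so its size is uncertain and a modest rise is the expectation. The expected step is a 2.5-fold higher number from compound 3 to compound 4 (0.40 log units; beyond the scatter). Compound 4 is estimated to give 50000 nM in this assay, within a range from 15000 nM to 200000 nM.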

Compound 4, half-maximal cytotoxic concentration: 25000 nM
Compound 4: middle estimate off by 2.0-fold (0.30 log units), on the high side; low and high end bracket the measured number.
By their numbers in this assay, from the lowest: compounds 3, 4 and 1 (each within the scatter of the next, the first and the last beyond it). At a limit, above all of these: compound 2.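

In this assay, the swap from pyrimidin-5-yl to 2-sulfamoylphenyl gives a 1.3-fold higher number from compound 3 to compound 4 (0.10 log units; within the scatter), so on this amide-type nitrogen the two groups cannot be told apart, even though one ring holds hetero atoms and the other is of carbon only. The comparison between two rings of carbon only gives a different result, with 2-sulfamoylphenyl in place of 4-fluorophenyl giving an at least 8.0-fold lower number from compound 2 to compound 4 (0.90 log units; beyond the scatter), which shows that a ring of carbon only is not enough on its own to keep the number as high as it is with 4-fluorophenyl, and that what the ring carries matters in this test. Compound 2 stands at a limit of the test and not at a number: the limit of > 200000 nM in this assay, at which 1 of the 4 values shown sits.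

The compounds shown do not separate the effect of the sulfamoyl group from the effect of losing the fluorine, and they do not show how a plain phenyl ring would behave on this nitrogen. As far as these compounds go, it also remains open whether a phenyl ring carrying an amine or a carboxylic acid in place of the sulfamoyl group would fall with compound 4 or nearer to compound 2.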